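From Trifluoromethyl to Bromo in an Antiproliferative Series

The source may hold more compounds than are shown below. What is called first, only, known or untested is meant among the compounds shown, and "the series" means these compounds.

In a functional assay on MCF7 cells (Homo sapiens) for antiproliferative activity, read by MTT assay, with a stated time of 72 h (a higher number here means a weaker inhibitor, a lower number a stronger inhibitor), compound 1 (`COc1ccc(/C=C2/CN(C)/C(=N/c3ccc(C)cc3)S2)cc1`) gives 7600 nM, while compound 2 (`COc1ccc(/C=C2/CN(C)/C(=N/c3ccc(C(F)(F)F)cc3)S2)cc1`) gives 24100 nM, the higher of the two numbers. Among the compounds with values here, the one measured step, a 3.2-fold higher number from compound 1 to compound 2 (0.50 log units; beyond the scatter), puts trifluoromethyl in place of methyl on an aromatic carbon; it is modest but beyond the scatter. Compound 3 (`COc1ccc(/C=C2/CN(C)/C(=N/c3ccc(Br)cc3)S2)cc1`) instead has bromo in place of trifluoromethyl on an aromatic carbon, para to a large group: bromo in place of trifluoromethyl on an aromatic carbon. No measurement covers this exchange directly, so the step to compound 2 from compound 1 offers only indirect guidance. A modest move towards a lower number is therefore expected, no larger than that measured step. The expected change is a 2.0-fold lower number from compound 2 to compound 3 (0.30 log units; within the scatter). For compound 3, the estimated value is 12000 nM, with an expected range of 5500 nM to 26000 nM.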

Compound 3, half-maximal inhibitory concentration: 7400 nM
The estimate for compound 3 lay 1.6-fold (0.21 log units) above the measured number; the range from low to high includes it.
By their numbers in this assay, from the lowest: compounds 3 and 1 (each within the scatter of the next); then compound 2.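

In this assay, bromo in place of trifluoromethyl on an aromatic carbon, para to a large group, gives a 3.3-fold lower number from compound 2 to compound 3 (0.51 log units; beyond the scatter), so the higher number seen with trifluoromethyl is not shared by every replacement of methyl at this position. Bromo in place of methyl gives a 1.0-fold lower number from compound 1 to compound 3 (0.01 log units; within the scatter), so methyl and bromo cannot be told apart here, and of the three compounds only compound 2 stands apart from the other two. Nothing available explains why trifluoromethyl differs from methyl and bromo at this position.

Going by these compounds, whether an amine or a carboxylic acid at this position would sit with methyl and bromo or with trifluoromethyl remains open. The compounds shown differ only at this position, so it also remains open whether these exchanges would read the same with a different group elsewhere on the shared core.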